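The source may hold more compounds than are shown below. What is called first, only, known or untested is meant among the compounds shown, and "the series" means these compounds.

Compound 2 `O=C(CC1Oc2cc(O)ccc2C=C1c1ccc(O)cc1)c1ccccc1` and compound 1 `CC(C)CC(=O)CC1Oc2cc(O)ccc2C=C1c1ccc(O)cc1` share one core and differ only in the group on a carbonyl carbon. In a functional assay on MDA-MB-231 cells (Homo sapiens) for antiproliferative activity, read by spectrophotometry and resazurin assay, with a stated time of 72 h (a higher number here means a weaker inhibitor, a lower number a stronger inhibitor), compound 2 gives 88000 nM and compound 1 gives 67000 nM; the step of a 1.3-fold higher number from compound 1 to compound 2 (0.12 log units; within the scatter) lies within the scatter, so the two compounds stand together. Compound 3 `Cc1cc(C2Oc3cc(O)ccc3C=C2c2ccc(O)cc2)cc(C)c1N` differs from compound 2 by 4-amino-3,5-dimethylphenyl in place of benzoylmethyl on a saturated ring carbon. Among the compounds with values here, no measured step touches this position, so the only step measured gives no direct guide. The step of a 1.5-fold lower number from compound 2 to compound 3 (0.17 log units; within the scatter) is therefore expected to stay small, with a wide range. Compound 3 is estimated at 60000 nM, between 12000 nM and 250000 nM.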

Compound 3, half-maximal inhibitory concentration: 53000 nM
The estimate for compound 3 lay 1.1-fold (0.05 log units) above the measured number; measured number inside the range.
By their numbers in this assay, from the lowest: compounds 3, 1 and 2 (each within the scatter of the next).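

In this assay, replacing either carbonyl-bearing group with 4-amino-3,5-dimethylphenyl on the saturated ring carbon gives a 1.7-fold lower number from compound 2 to compound 3 (0.22 log units; within the scatter) and a 1.3-fold lower number from compound 1 to compound 3 (0.10 log units; within the scatter). This position therefore holds three quite different groups, including one with an aromatic ring joined directly to the ring carbon and no carbonyl, without the numbers separating. No supporting evidence bears on this result. The compounds shown leave open whether a much smaller group at this carbon, such as methyl, or a carboxylic acid on the incoming phenyl ring would move the number beyond the scatter.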